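The source may hold more compounds than are shown below. What is called first, only, known or untested is meant among the compounds shown, and "the series" means these compounds.

Measured in a functional assay on A549 cells (Homo sapiens) for cytotoxicity, read by MTT assay, with a stated time of 48 h; on this read-out higher numbers stand for weaker inhibition and lower numbers for stronger inhibition:
- Compound 1 `Cc1ccc(C2=NO[C@@H]3[C@H](CO)C[C@H](CO)[C@H]23)cc1`: > 50 ug/mL, which is a limit of the assay and not a number
- Compound 2 `COc1ccc(C2=NO[C@@H]3[C@H](CO)C[C@H](CO)[C@H]23)cc1`: 36.6 ug/mL

Going by the values given here, compound 2, at 36.6 ug/mL, holds the only true number so far, so there is no series to rank it against. the limit of > 50 ug/mL in this assay, at which 1 of the 2 values shown sits, is all that compound 1 adds. Compound 3 `COc1ccc(C2=NO[C@@H]3[C@H](CO)C[C@H](CO)[C@H]23)cc1OC` is compound 2 with one further group on the aromatic ring: methoxy in place of hydrogen on an aromatic carbon. This new methoxy sits ortho to the existing methoxy group.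

Among the compounds with values here, only one measured step bears on this change: an at least 1.3-fold lower number from compound 1 to compound 2 (0.13 log units; that floor lies within the scatter). That step also involves a methoxy group, but it is a different swap, and its size is only a floor. It therefore gives no firm reason to expect a real shift in this assay, in either direction. The expected step is a 1.0-fold lower number from compound 2 to compound 3 (0.02 log units; within the scatter), which would not stand out from the scatter. For compound 3 the estimated value is 35 ug/mL, with an expected range from 17 ug/mL to 60 ug/mL.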

Compound 3, half-maximal inhibitory concentration: > 50 ug/mL
Compound 3: no number, only a limit (the forecaster's own chance of this, stated with the estimate: 25%); middle value at least 1.4-fold (0.15 log units) from the limit.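

Compound 3 gives > 50 ug/mL in this assay, which is a limit of the assay and not a number. The step is an at least 1.3-fold higher number from compound 2 to compound 3 (0.13 log units; that floor lies within the scatter), so a second methoxy, ortho to a methoxy group, brought no sign of stronger inhibition, though the true size of the change cannot be read from a floor. The earlier compounds had not tested this place on the ring, and compound 2 remains the only one with a true number: the limit of > 50 ug/mL in this assay, at which 2 of the 3 values shown sit.

On these data alone, how compound 1 and compound 3 truly compare with compound 2 stays open, since their values lie beyond the limit. Also open, as far as these compounds go, is whether a different group at this place, such as a hydroxyl, a fluorine or an amine, would behave any differently from methoxy.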